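A few compounds are considered here, and "the series" means these few. Any claim that something is new, unique, unknown or untested is made for them only; others in the source may bear on it.

For the measured compounds named here, compound 1 `Cc1ccc(NC(=S)NC(=O)c2cn(-c3ccccc3)nc2-c2ccc(Cl)cc2)cc1` was tested in a functional assay on A549 cells (Homo sapiens) for inhibition, read by CCK-8 assay, with a stated time of 48 h (on this read-out lower numbers stand for stronger inhibition and higher numbers for weaker inhibition), where compound 1 gives 2690 nM, the higher of the two numbers so far. Going by the values given here, the only other tested compound, compound 2 `COc1ccc(NC(=S)NC(=O)c2cn(-c3ccccc3)nc2-c2ccc(OC)cc2)cc1`, gives 750 nM in this assay. Compound 3 `Cc1ccc(NC(=S)NC(=O)c2cn(-c3ccccc3)nc2-c2ccc(C)cc2)cc1` differs from compound 1 by methyl in place of chloro on an aromatic carbon. Among the compounds with values here, no measured pair isolates this change, so the step is expected to stay within the scatter, with no clear direction. The expected step is a 1.1-fold lower number from compound 1 to compound 3 (0.03 log units; within the scatter). Compound 3 is therefore estimated at 2500 nM, within 1000 nM to 6500 nM.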

Compound 3, half-maximal inhibitory concentration: 2830 nM
Compound 3: the middle estimate sits 1.1-fold (0.05 log units) below what was measured, and the stated range covers the measured number.
By their numbers in this assay, from the lowest: compound 2; then compounds 1 and 3 (each within the scatter of the next).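

In this assay methyl in place of chloro on an aromatic carbon, para to a large group, gives a 1.1-fold higher number from compound 1 to compound 3 (0.02 log units; within the scatter) and so leaves the number within the scatter at this position. For the compounds shown here, compounds 1 and 2 differ in more than one place, so this is the first comparison to isolate a single change, and 4-chlorophenyl and 4-methylphenyl cannot be told apart here. No measurement at hand accounts for this result. Still open, as far as these compounds go, is whether another group at this position, such as an amine or a carboxylic acid, would move the number beyond the scatter.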